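Meta-substituent changes on the benzoate of the shared core

The source may hold more compounds than are shown below. What is called first, only, known or untested is meant among the compounds shown, and "the series" means these compounds.

Going by the values given here, compound 2 `CC1=CC[C@H](C(C)C)c2cc(C)c(OC(=O)c3cccc(Cl)c3)cc21` is one of two compounds measured in a functional assay on SK-LU-1 cells (Homo sapiens) for antiproliferative activity, read by sulforhodamine B assay, with a stated time of 48 h, tested at 50 uM; a lower number here means less inhibition, a higher number more inhibition at the concentration tested (going by the name of the read-out); compound 2 gives 30.6% and compound 1 `COc1cccc(C(=O)Oc2cc3c(cc2C)[C@@H](C(C)C)CC=C3C)c1` gives 24.2%. Among the compounds with values here, the only measured step is a number 6.4 percentage points higher from compound 1 to compound 2 (within the scatter), a change of the substituent on the benzoate ring that left the read-out within the scatter. Compound 3 `CC1=CC[C@H](C(C)C)c2cc(C)c(OC(=O)c3cccc([N+](=O)[O-])c3)cc21` carries the next change at the same place, (nitro in place of chloro on an aromatic carbon). Within the data shown here, that one step is the sole guide, and it suggests no movement beyond the scatter. For compound 3 the expected step is a number 1.4 percentage points higher from compound 2 to compound 3 (within the scatter), giving an estimate of 32%, with a range from 18% to 46%.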

Compound 3, a percentage reported as inhibition, at one concentration (the size of the read-out at that concentration, not a potency): 60.4%
Compound 3: the middle estimate sits 28.4 percentage points below what was measured; measured number above the stated range.
By their numbers in this assay, from the lowest: compounds 1 and 2 (each within the scatter of the next); then compound 3.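

At this position the benzoate substituent can move the read-out in this assay: nitro in place of chloro gives a clear gain (a number 29.8 percentage points higher from compound 2 to compound 3 (beyond the scatter)), and nitro in place of methoxy gives a larger one (a number 36.2 percentage points higher from compound 1 to compound 3 (beyond the scatter)). The earlier chloro and methoxy pair gave no sign of this. No data at hand account for the gain.

On these data alone, whether the gain is particular to nitro remains open. An amine, a nitrile or a carboxylic acid at the same place on the shared core would help to settle this.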